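This account rests on a few compounds, and the source may have more. Where it says the series, first, only, none or still open, it means among the compounds named here.

Compound 1 `CNc1nc(-c2cc(OC)c(OC)c(OC)c2)c(-c2ccc(C(F)(F)F)cc2)s1` gives 3400 nM in a functional assay on HeLa cells (Homo sapiens) for antiproliferative activity, read by MTT assay, with a stated time of 72 h; on this read-out lower numbers stand for stronger inhibition and higher numbers for weaker inhibition. Compound 2 `CNc1nc(-c2cc(OC)c(OC)c(OC)c2)c(-c2ccc(OC)cc2)s1` gives 70.1 nM in this assay. Compound 3 `COc1cc(-c2nc(N(C)C)sc2-c2ccc(C(F)(F)F)cc2)cc(OC)c1OC` reaches only a limit in this assay, > 10000 nM; that value is a limit, not a number, as in the limit of > 10000 nM in this assay, at which 1 of the 3 values shown sits.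

The change from compound 1 to compound 2 is methoxy in place of trifluoromethyl on an aromatic carbon, and it produced a 49-fold lower number from compound 1 to compound 2 (1.69 log units; beyond the scatter). The cores of compound 1 and compound 3 differ by methyl in place of hydrogen on a nitrogen on an aromatic ring, which produced an at least 2.9-fold higher number from compound 1 to compound 3 (0.46 log units; beyond the scatter). Compound 4 `COc1ccc(-c2sc(N(C)C)nc2-c2cc(OC)c(OC)c(OC)c2)cc1` carries the same change on the core of compound 3: methoxy in place of trifluoromethyl on an aromatic carbon, at a place described in the same words as before.

The step from compound 3 to compound 4 is expected to be an at least 25-fold lower number from compound 3 to compound 4 (1.39 log units; beyond the scatter), set beside a 49-fold lower number from compound 1 to compound 2 (1.69 log units; beyond the scatter); this rests on compound 2 at 70.1 nM and on the step of an at least 2.9-fold higher number from compound 1 to compound 3 (0.46 log units; beyond the scatter) seen for the added methyl on nitrogen. Compound 4 is therefore expected to give about 400 nM in this assay, plausibly between 100 nM and 3000 nM.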

Compound 4, half-maximal inhibitory concentration: 3370 nM
Estimate against measurement, compound 4: 8.4-fold (0.93 log units) below, and the stated range ends below it.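

Methoxy in place of trifluoromethyl also lowers the number in this assay on the core of compound 3, an at least 2.9-fold lower number from compound 3 to compound 4 (0.47 log units; beyond the scatter), so the direction of this change carries over from one core to the other. Compound 3 stands at a limit, > 10000 nM, so the size of the change on its core stays unknown and cannot be matched against the first core: the same change on two cores in this assay, a 49-fold lower number (1.69 log units; beyond the scatter) from compound 1 to compound 2 and an at least 2.9-fold lower number (0.47 log units; beyond the scatter) from compound 3 to compound 4; the limit leaves it open whether they differ The added methyl on nitrogen likewise raises the number with methoxy in place, a 48-fold higher number from compound 2 to compound 4 (1.68 log units; beyond the scatter), but here too the direction holds and a comparison of size does not: the same change on two cores in this assay, an at least 2.9-fold higher number (0.46 log units; beyond the scatter) from compound 1 to compound 3 and a 48-fold higher number (1.68 log units; beyond the scatter) from compound 2 to compound 4; the limit leaves it open whether they differ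

As far as these compounds go, whether a chlorine or a hydroxyl group in place of methoxy, or an ethyl group or longer chain on the nitrogen, would follow the same direction stays open.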